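This account rests on a few compounds, and the source may have more. Where it says the series, first, only, none or still open, it means among the compounds named here.

Measured in a functional assay on MCF7 cells (Homo sapiens) for antiproliferative activity, read by MTT assay, with a stated time of 72 h; on this read-out lower numbers stand for stronger inhibition and higher numbers for weaker inhibition:

- compound 1 `FC(F)(F)c1ccc(COc2cccc(Nc3ncnc4cc5c(cc34)OCCOCCOCCOCCO5)c2)cc1` gives 8480 nM
- compound 3 `O=[N+]([O-])c1ccc(COc2cccc(Nc3ncnc4cc5c(cc34)OCCOCCOCCOCCO5)c2)cc1` gives 6410 nM
- compound 2 `FC(F)(F)c1ccc(COc2ccccc2Nc2ncnc3cc4c(cc23)OCCOCCOCCO4)cc1` reaches only the limit of the assay, > 100000 nM

Compound 1 and compound 3 share one core and differ by nitro in place of trifluoromethyl on an aromatic carbon. In this assay this change made a 1.3-fold lower number from compound 1 to compound 3 (0.12 log units; within the scatter), so the two values do not separate from each other.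

For compound 2 the assay gives no number, only (the limit of > 100000 nM in this assay, at which 1 of the 3 values shown sits). How the core of compound 2 differs from the core of compound 1 is not broken down here.

Compound 4 `O=[N+]([O-])c1ccc(COc2ccccc2Nc2ncnc3cc4c(cc23)OCCOCCOCCO4)cc1` stands to compound 2 as compound 3 stands to compound 1: the change is nitro in place of trifluoromethyl on an aromatic carbon, made at the same place, so it is the same change. Because the earlier step was a 1.3-fold lower number from compound 1 to compound 3 (0.12 log units; within the scatter), the step from compound 2 to compound 4 is expected to be small as well, and since compound 2 is known only by a limit, compound 4 is most likely to sit at that limit too. The estimated step is a step that the limit leaves unreadable from compound 2 to compound 4. Compound 4 is thus expected at about 120000 nM, with a range from 20000 nM to 600000 nM, pending the measurement.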

Compound 4, half-maximal inhibitory concentration: > 100000 nM
Compound 4 gave a limit, no number (the forecaster's own chance of this, stated with the estimate: 70%); the middle value lies beyond the limit too.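

Compound 4, like compound 2, reaches only a limit in this assay, so no step between the two can be read: the limit of > 100000 nM in this assay, at which 2 of the 4 values shown sit.

The compounds shown leave open whether nitro in place of trifluoromethyl makes any difference on the core shared by compound 2 and compound 4, since neither gives a number.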